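A few compounds are considered here, and "the series" means these few. Any claim that something is new, unique, unknown or untested is made for them only; others in the source may bear on it.

Measured so far in an ADME assay on MT4 cells (Homo sapiens) for cytotoxicity, read by MTT assay; on this read-out lower numbers stand for higher toxicity in this test and higher numbers for lower toxicity in this test:
- compound 1, `CCCCCOc1ccc(C(=O)N(C(=S)OCCN2C(=O)c3ccccc3C2=O)c2ccc(F)cc2)cc1`, > 100000 nM 
- compound 2, `Cc1cccc(C(=O)N(C(=S)OCCN2C(=O)c3ccccc3C2=O)c2ccc(Cl)cc2)c1`, 58000 nM 
- compound 3, `Cc1ccc(N(C(=O)c2ccccc2[N+](=O)[O-])C(=S)OCCN2C(=O)c3ccccc3C2=O)cc1`, 100000 nM 

Three compounds on one shared core have been run through this assay. For compound 1 the result is not a number but a limit of the assay, (the limit of > 100000 nM in this assay, at which 1 of the 3 values shown sits). Compound 2 gives the lowest of the two numbers, with compound 3 as its nearest neighbour at a value that sits within the usual scatter of this assay, so no order between compound 2 and compound 3 can be read from these two results.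

The step under consideration leads from compound 2 to compound 4, `O=C1c2ccccc2C(=O)N1CCOC(=S)N(C(=O)c1ccc(Cl)cc1Cl)c1ccc(Cl)cc1`, which has not yet been measured in this assay. The change is 2,4-dichlorophenyl in place of 3-methylphenyl on a carbonyl carbon.

Within the data shown here, no measured pair differs in a single place here, so there is no comparable step to lean on. Given that compound 2 gives 58000 nM, the step from compound 2 to compound 4 is expected to be small, a 1.3-fold lower number from compound 2 to compound 4 (0.11 log units; within the scatter), possibly toward a lower number but not clearly beyond the scatter. Compound 4 is therefore estimated at 45000 nM, in a range from 15000 nM to 100000 nM.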

Compound 4, half-maximal cytotoxic concentration: 18000 nM
Compound 4: middle estimate off by 2.5-fold (0.40 log units), on the high side; the measured number falls inside the stated range.
By their numbers in this assay, from the lowest: compound 4; then compounds 2 and 3 (each within the scatter of the next).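

In this assay, the group on a carbonyl carbon whose other neighbours are the amide-type nitrogen proves able to move the number: 2,4-dichlorophenyl in place of 3-methylphenyl gives a 3.2-fold lower number from compound 2 to compound 4 (0.51 log units; beyond the scatter). Among these compounds, the earlier compounds offered no pair differing in one place, so this is the first single change on the shared core that can be read, and it runs toward higher toxicity in this test. Nothing given here bears on why the number moves with this change.

As far as these compounds go, whether either chlorine alone would give this step remains open, as does what an amine, a carboxylic acid or a longer chain would do in the same place. From the compounds shown here alone, the step also stands alone, so whether the same change would give a like step elsewhere is unknown.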